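From 2-bromoethoxy to (5-bromopentyl)oxy

This account rests on a few compounds, and the source may have more. Where it says the series, first, only, none or still open, it means among the compounds named here.

In a functional assay on A549 cells (Homo sapiens) for antiproliferative activity, read by MTT assay, with a stated time of 48 h (a higher number here means a weaker inhibitor, a lower number a stronger inhibitor), compound 1 `COc1ccc(N(C)c2ccnc(Cl)n2)cc1Cl` gives 621 nM, while compound 2 `COc1ccc(N(C)c2ccnc(Cl)n2)cc1OCCBr` gives 4640 nM, the higher and so weaker of the two numbers. Compound 3 `COc1ccc(N(C)c2ccnc(Cl)n2)cc1OCCCCCBr` differs from compound 2 in one place, with (5-bromopentyl)oxy in place of 2-bromoethoxy: 3-bromopropyl in place of bromo on a saturated chain carbon, two bonds along the chain from an oxygen on an aromatic ring. For the measured compounds named here, only one measured step bears on this, the modest 7.5-fold higher number from compound 1 to compound 2 (0.87 log units; beyond the scatter), and it is a different change, so it offers no direction. No step beyond the scatter is therefore expected in this assay. The estimated step is a 1.2-fold lower number from compound 2 to compound 3 (0.06 log units; within the scatter). For compound 3 the expected value is 4000 nM, within an estimated range of 1300 nM to 12000 nM.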

Compound 3, half-maximal inhibitory concentration: 9720 nM
Estimate against measurement, compound 3: 2.4-fold (0.39 log units) below, and the stated range covers the measured number.
By their numbers in this assay, from the lowest: compound 1; then compound 2; then compound 3.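

Lengthening the chain on this oxygen does not bring the number back down in this assay: going from 2-bromoethoxy to (5-bromopentyl)oxy gives a 2.1-fold higher number from compound 2 to compound 3 (0.32 log units; beyond the scatter), a modest step beyond the scatter. Against the original chloro group, the longer chain gives a 16-fold higher number from compound 1 to compound 3 (1.19 log units; beyond the scatter), a large step, so compound 3 loses more than compound 2 did. Nothing measured here accounts for this rise.

Still open, going by these compounds, are whether a longer chain would raise the number further and whether an amine in place of the bromo at the chain end would change it.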